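Chloro added to the styryl end: cytotoxicity on skin cells

The source may hold more compounds than are shown below. What is called first, only, known or untested is meant among the compounds shown, and "the series" means these compounds.

Measured compounds:
- compound 1, `NS(=O)(=O)c1cc(-c2nnc(CN3CCN(c4ccc(Cl)cc4)CC3)o2)c(Cl)cc1SCc1ccccc1`, 115000 nM
- compound 2, `NS(=O)(=O)c1cc(-c2nnc(Cn3cc(-c4ccccc4)nn3)o2)c(Cl)cc1SCc1ccccc1`, 300000 nM
- compound 3, `NS(=O)(=O)c1cc(-c2nnc(/C=C/c3ccccc3)o2)c(Cl)cc1SCc1ccccc1`, 20000 nM

The three compounds share one core and differ in the group attached to it. In an ADME assay on HaCaT cells (Homo sapiens) for cytotoxicity, read by MTT assay, with a stated time of 72 h (a higher number here means a weaker inhibitor, a lower number a stronger inhibitor), compound 3 gives the lowest number of the three, so it is the strongest inhibitor here. Its nearest neighbour is compound 1, and the gap to compound 2 is wider still. Among the measured compounds shown here, the only single change that can be traced between measured compounds is a 15-fold lower number from compound 2 to compound 3 (1.18 log units; beyond the scatter), a large step.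

Compound 4, `NS(=O)(=O)c1cc(-c2nnc(/C=C/c3cccc(Cl)c3)o2)c(Cl)cc1SCc1ccccc1`, has not yet been measured. It is built from compound 3 by one change: chloro in place of hydrogen on an aromatic carbon. For the measured compounds named here, nothing among the measured compounds tests a change of this kind; the one measured step swaps a whole side group rather than adding a single atom to a ring. There is therefore no basis for expecting a large move in either direction, and the expected step is no change at the digits printed from compound 3 to compound 4 (within the scatter), within the usual scatter. Compound 4 is expected to give about 20000 nM in this assay, most likely between 8000 nM and 50000 nM.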

Compound 4, half-maximal inhibitory concentration: 16000 nM
Estimate against measurement, compound 4: 1.3-fold (0.10 log units) above, within the range that was stated.
By their numbers in this assay, from the lowest: compounds 4 and 3 (each within the scatter of the next); then compound 1; then compound 2.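

In this assay, among the compounds shown here, the step for chloro in place of hydrogen on an aromatic carbon, meta to a large group, is a 1.3-fold lower number from compound 3 to compound 4 (0.10 log units; within the scatter), and this is the first single-atom change that can be read, since the earlier step swapped a whole side group. At this place on the six-membered aromatic ring, then, a chlorine can be carried without a shift that stands out from the scatter of repeated measurements, and phenyl and 3-chlorophenyl read alike at the end of the ethenyl link. The large gap to the triazole-bearing side group is also still there with the chlorine present, as a 19-fold lower number from compound 2 to compound 4 (1.27 log units; beyond the scatter), but nothing shown explains why the chloro leaves the number so little changed.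

Going by these compounds, one atom at one place is a narrow test, so it remains open whether a methoxy group, an amine or a carboxylic acid at the same place would also stay within the scatter. On these data alone, it is equally open whether chloro on a different carbon of that ring, or a longer chain between the ring and the shared core, would move the number in this skin-cell assay.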